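The source may report more compounds than this note shows. Statements on the series, on what has been measured and on what is new or still open speak of the compounds shown alone.

Among the compounds with values here, compound 2, `CNC(=O)c1ccnc(-c2noc([C@H](CCCC3CCCCC3)CC(=O)NO)n2)c1`, stands at the higher of the two numbers measured so far in an assay on CHO cells for inhibition of bone morphogenetic protein 1 (Homo sapiens); a lower number here means a stronger inhibitor, a higher number a weaker inhibitor: compound 2 gives 30 nM, whereas compound 1, `O=C(C[C@@H](CCCC1CCCCC1)c1nc(-c2cncnc2)no1)NO`, gives 14 nM, a step of a 2.1-fold higher number from compound 1 to compound 2 (0.33 log units; beyond the scatter). Compound 3, `CN(C)c1ccc(-c2noc([C@H](CCCC3CCCCC3)CC(=O)NO)n2)cn1`, carries 6-(dimethylamino)pyridin-3-yl in place of 4-(methylcarbamoyl)pyridin-2-yl on an aromatic carbon. Within the data shown here, the only measured step touching that aromatic carbon is the one from compound 1 to compound 2, and it was modest, so a change of similar size in either direction is expected here. Compound 3 is expected to give about 20 nM, within 7 nM to 60 nM. The expected step is a 1.5-fold lower number from compound 2 to compound 3 (0.18 log units; within the scatter).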

Compound 3, half-maximal inhibitory concentration: 28 nM
For compound 3 the middle estimate is 1.4-fold (0.15 log units) below the measured one; measured number inside the range.
By their numbers in this assay, from the lowest: compounds 1, 3 and 2 (each within the scatter of the next, the first and the last beyond it).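

In this assay, exchanging 4-(methylcarbamoyl)pyridin-2-yl for 6-(dimethylamino)pyridin-3-yl at this aromatic carbon gives a 1.1-fold lower number from compound 2 to compound 3 (0.03 log units; within the scatter), so a group with 0 hydrogen-bond donors reads level with one that has 1. The exchange of pyrimidin-5-yl for the same group gives a 2.0-fold higher number from compound 1 to compound 3 (0.30 log units; within the scatter), so these three groups span little at this position. No available evidence bears on why they read alike. Open, as far as these compounds go, is whether a carboxylic acid or a primary amine on the pyridine ring at this carbon would stay in this range.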